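From a double ester to a single ester

The source may report more compounds than this note shows. Statements on the series, on what has been measured and on what is new or still open speak of the compounds shown alone.

Measured in a functional assay on RAW264.7 cells (Mus musculus) for inhibition; on this read-out lower numbers stand for stronger inhibition and higher numbers for weaker inhibition:
compound 1 `COc1cc(/C=C/C(=O)CC(=O)/C=C/c2ccc(OC(=O)c3ccccc3OC(=O)c3ccccc3O)c(OC)c2)ccc1O`: > 30000 nM
compound 2 `COc1cc(/C=C/C(=O)CC(=O)/C=C/c2ccc(OC(=O)C(C)c3ccc(CC(C)C)cc3)c(OC)c2)ccc1O`: > 30000 nM
compound 3 `COc1cc(/C=C/C(=O)CC(=O)/C=C/c2ccc(OC(=O)c3ccccc3OC(C)=O)c(OC)c2)ccc1OC(=O)c1ccccc1OC(C)=O`: > 30000 nM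

In this assay compound 3 gives > 30000 nM, a limit and not a number. The whole set shares this position: the limit of > 30000 nM in this assay, at which 3 of the 3 values shown sit. Compound 4 `COc1cc(/C=C/C(=O)CC(=O)/C=C/c2ccc(OC(=O)c3ccccc3OC(C)=O)c(OC)c2)ccc1O` differs from compound 3 by one change: hydrogen in place of (2-acetoxyphenyl)carbonyl on an oxygen on an aromatic ring. Within the data shown here, no measured pair shows this change directly. Little is expected from it because compound 1, which has that hydrogen, gives > 30000 nM, also a limit. Compound 2 has that hydrogen too and gives > 30000 nM, again a limit. Only a small step towards stronger inhibition is expected in this assay: an at least 1.2-fold lower number from compound 3 to compound 4 (0.07 log units; that floor lies within the scatter). For compound 4 the estimate is 25000 nM, with an expected range from 8000 nM to 60000 nM.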

Compound 4, half-maximal inhibitory concentration: > 30000 nM
Compound 4: no number, only a limit (the forecaster's own chance of this, stated with the estimate: 65%); middle value at least 1.2-fold (0.07 log units) away from the limit.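

In this assay compound 4 gives > 30000 nM, a limit and not a number. Its steps from compound 1, compound 2 and compound 3 therefore cannot be read: the limit of > 30000 nM in this assay, at which 4 of the 4 values shown sit.

The compounds shown leave open how strongly any of them inhibits.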